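The source may hold more compounds than are shown below. What is called first, only, known or untested is meant among the compounds shown, and "the series" means these compounds.

Measured so far:
Compound 1 (`O=S(=O)(/C=C/c1ccccc1)Cc1ccc(Nc2ncnc3ccccc23)cc1`): > 100000 nM
Compound 2 (`O=S(=O)(/C=C/c1ccc(Cl)cc1Cl)Cc1ccc(Nc2ncnc3ccccc23)cc1`): 2000 nM

Among the compounds with values here, in a functional assay on UACC-62 cells (Homo sapiens) (on this read-out higher numbers stand for weaker inhibition of growth and lower numbers for stronger inhibition of growth), compound 2 gives 2000 nM and holds the only true number so far. Compound 1 gives > 100000 nM and this is a limit of the assay, not a number. Compound 3 (`O=S(=O)(/C=C/c1ccc(Cl)cc1Cl)Cc1ccc(Nc2ncnc3cc(Cl)ccc23)cc1`) differs from compound 2 by chloro in place of hydrogen on an aromatic carbon. Within the data shown here, only one measured step exists (an at least 50-fold lower number from compound 1 to compound 2 (1.69 log units; beyond the scatter)), and it was large, but it lies at another place in the molecule. It therefore shows that large steps occur in this series, yet gives neither size nor direction for the new change. No step beyond the scatter is thus expected in this assay for this change. The expected change is small (a 1.3-fold lower number from compound 2 to compound 3 (0.12 log units; within the scatter)). For compound 3 the estimated value is 1500 nM (expected range 400 nM to 6000 nM).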

Compound 3, concentration for 50% growth inhibition: 32000 nM
For compound 3 the middle estimate is 21-fold (1.33 log units) below the measured one; measured number above the stated range.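

In this assay, chloro in place of hydrogen on an aromatic carbon of the fused system is far from a neutral change: it gives a 16-fold higher number from compound 2 to compound 3 (1.20 log units; beyond the scatter), a clear loss of growth inhibition. Within the data shown here, this is the first step seen at this position, and it shows that one added chlorine atom here is enough to move the result well beyond the scatter. The earlier step at the other place, an at least 50-fold lower number from compound 1 to compound 2 (1.69 log units; beyond the scatter), ran the opposite way, so across compounds 1, 2 and 3 adding chloro does not act alike at the two places.

As far as these compounds go, whether the loss is particular to chloro stays open, as does the outcome with fluoro, methoxy or an amine on this carbon, or with chloro on another carbon of the same ring. The data given here offer no explanation for the loss.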